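Swapping a methylpyridyl for a chlorophenyl: a lipophilicity forecast

This account rests on a few compounds, and the source may have more. Where it says the series, first, only, none or still open, it means among the compounds named here.

Measured so far:
compound 1 `CC[C@@H](Nc1c(C#N)c(-c2ccc(-c3ccncc3C)cc2)nc2cnccc12)C(N)=O`, 2
compound 2 `CCOc1ccccc1-c1ccc(-c2nc3cnccc3c(N)c2C#N)cc1`, 3
compound 3 `CCOc1ccccc1-c1ccc(-c2nc3cnccc3c(C[C@H](C)C(N)=O)c2C#N)cc1`, 3

These three were measured in a physicochemical assay for lipophilicity, read by HPLC, at pH 7.5; a higher number here means a more lipophilic compound, a lower number a more polar compound. Compound 1 gives the lowest number of the three; compound 2 and compound 3 each sit higher by a gap beyond the scatter. For the measured compounds named here, the only step between two measured compounds is no change at the digits printed from compound 2 to compound 3 (within the scatter), and it changes a different part of the molecule.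

Compound 4 `CC[C@@H](Nc1c(C#N)c(-c2ccc(-c3cccc(Cl)c3)cc2)nc2cnccc12)C(N)=O` differs from compound 1 in one place: 3-chlorophenyl in place of 3-methylpyridin-4-yl on an aromatic carbon. Going by the values given here, no measured step covers this exchange, so the expectation rests on the change itself, in which a ring bearing one nitrogen and one hydrogen-bond acceptor gives way to a carbon-only ring bearing chlorine and no acceptor. Compound 4 is therefore expected to be more lipophilic than compound 1, by an estimated a number 1.50 log units higher from compound 1 to compound 4 (beyond the scatter). The estimate for compound 4 is 3.5, within 2.8 to 4.2.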

Compound 4, distribution coefficient: 3.1
Estimate against measurement, compound 4: 0.40 log units above; the range from low to high includes it.
By their numbers in this assay, from the lowest: compound 1; then compounds 2, 3 and 4 (each within the scatter of the next).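

This position on the carbon-only ring now has a measured step. In this assay, for the compounds shown here, 3-chlorophenyl in place of 3-methylpyridin-4-yl gives a number 1.10 log units higher from compound 1 to compound 4 (beyond the scatter), whereas the only earlier step, made elsewhere on the molecule, showed no change. No measurement shown here accounts for the size of this step.

As far as these compounds go, the exchange replaces the ring nitrogen and the methyl and adds the chlorine all at once, so the share of each stays open. The compounds shown also leave open how a plain phenyl or a pyridine ring bearing an amine would read at this position.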